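Replacing a chain with a chloropyrimidine ring on the carbonyl

The source may hold more compounds than are shown below. What is called first, only, known or untested is meant among the compounds shown, and "the series" means these compounds.

Compound 1 `Cc1nc(S(C)(=O)=O)ccc1Oc1ncnc(OC2CCN(C(=O)O[C@@H](C)CF)CC2)c1F`: 84%
Compound 2 `Cc1nc(S(C)(=O)=O)ccc1Oc1ncnc(OC2CCN(C(=O)OC3(C(F)(F)F)CCC3)CC2)c1F`: 82%
Compound 3 `Cc1nc(S(C)(=O)=O)ccc1Oc1ncnc(OC2CCN(C(=O)c3noc(C(C)(C)F)n3)CC2)c1F`: 74%

Of the compounds shown here, three sharing one core have been measured in a functional assay on isolated protein for inhibition of Glucose-dependent insulinotropic receptor (Rattus norvegicus), read by HTRF and cAMP accumulation; on this read-out higher numbers stand for larger maximal responses and lower numbers for smaller maximal responses. Compound 1 shows the largest of the three numbers, yet both other values lie within the usual scatter of it: a number 2 percentage points lower from compound 1 to compound 2 (within the scatter) and a number 10 percentage points lower from compound 1 to compound 3 (within the scatter). Among these three, therefore, no real difference in maximal response can be claimed.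

Compound 4 `Cc1nc(S(C)(=O)=O)ccc1Oc1ncnc(OC2CCN(C(=O)c3ncc(Cl)cn3)CC2)c1F` has not yet been measured. It differs from compound 1 in one place: a group of 7 heavy atoms (4 carbon, 2 nitrogen, 1 chlorine; one six-membered aromatic ring with 2 hetero atoms) in place of a group of 5 heavy atoms (3 carbon, 1 oxygen, 1 fluorine; no ring), on a carbonyl carbon. The measured step that bears most on this change is the one where an aromatic ring with hetero atoms likewise replaced the same chain on the carbonyl carbon: a number 10 percentage points lower from compound 1 to compound 3 (within the scatter). A second step in which an aromatic ring entered on the carbonyl carbon points the same way, also within the scatter: a number 8 percentage points lower from compound 2 to compound 3 (within the scatter). Since both steps stayed within the scatter, compound 4 is expected to show a step of a number 7 percentage points lower from compound 1 to compound 4 (within the scatter), nothing beyond the scatter. The estimate for compound 4 is 77%, expected to fall between 64% and 90%.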

Compound 4, largest response reached (reported as efficacy), in percent of the reference or control that the assay uses: 77%
Compound 4: middle estimate and measured number agree at the digits printed, within the range that was stated.
By their numbers in this assay, from the lowest: compounds 3, 4, 2 and 1 (each within the scatter of the next).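

In this assay, within the data shown here, the 5-chloropyrimidin-2-yl group brings a six-membered aromatic ring onto the carbonyl carbon for the first time, and replacing the chain with it gives a number 7 percentage points lower from compound 1 to compound 4 (within the scatter) as the result of this change. The two aromatic rings can now be compared directly, with a number 3 percentage points higher from compound 3 to compound 4 (within the scatter) for that swap, while the group with the four-membered ring gives way to the new ring with a number 5 percentage points lower from compound 2 to compound 4 (within the scatter) as its step. Across these four compounds, then, the carbonyl carbon carries a chain, a four-membered ring and two kinds of aromatic ring with no real difference in maximal response.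

No measurement at hand explains why these groups read alike. As far as these compounds go, whether an amine or a carboxylic acid on this carbonyl carbon would give a step beyond the scatter remains open.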